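Amide variation on the shared core: cytotoxicity notes

The source may report more compounds than this note shows. Statements on the series, on what has been measured and on what is new or still open speak of the compounds shown alone.

Measured compounds:
compound 1, `Cn1c(-c2ccccc2)cnc1NC(=O)c1cccc(Cl)c1`, > 50000 nM
compound 2, `Cc1ccccc1C(=O)Nc1ncc(-c2ccccc2)n1C`, > 100000 nM

Both values shown for a toxicity assay on THP-1 cells (Homo sapiens) for inhibition (on this read-out lower numbers stand for higher toxicity in this test and higher numbers for lower toxicity in this test), are limits of the assay, not numbers. Compound 1 sits at > 50000 nM, a limit. Compound 2 sits at > 100000 nM, likewise a limit. Among the measured compounds shown here, the only measured step, 2-methylphenyl in place of 3-chlorophenyl on a carbonyl carbon, is a step that the two limits leave unreadable from compound 1 to compound 2; with the limit of > 100000 nM in this assay, at which 1 of the 2 values shown sits, and the limit of > 50000 nM in this assay, at which 1 of the 2 values shown sits, bounding the two ends, its size cannot be read. Compound 2 therefore stands at the upper limit of the measurement, with no number behind it and no readable step leading to it.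

Compound 3 is `Cn1c(-c2ccccc2)cnc1NC(=O)C1CCCCC1`. It differs from compound 2 by cyclohexyl in place of 2-methylphenyl on a carbonyl carbon. For the measured compounds named here, no measured step touches cyclohexyl, and the single step in hand is unreadable, so neither direction nor size can be borrowed from it. The expectation for compound 3 is a step of a number no higher from compound 2 to compound 3 (the limit leaves the size open), that is, none beyond the scatter, with compound 3 most probably again reported only as a limit. The estimate for compound 3 in this assay is 100000 nM, within a range of 40000 nM to 250000 nM.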

Compound 3, half-maximal cytotoxic concentration: > 100000 nM
Compound 3: a limit, no number; the forecaster's own chance of this, stated with the estimate: 80%; the middle value lies on the limit itself.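

In this assay compound 3 gives > 100000 nM, a limit and not a number. With compound 1 and compound 2 also standing only as limits, no step among these compounds can be read. The compounds shown leave open whether any of these amides reaches a measurable cytotoxic concentration, and how far 3-chlorophenyl, 2-methylphenyl and cyclohexyl differ.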